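The compounds below may be only part of what the source reports. "The series", "measured", "known", "first", "only" and "open" are said of these compounds alone.

Series notes. Compound 1 `CC[C@@H](Nc1c(C#N)c(-c2ccc(-c3ncccc3C)cc2)nc2cnccc12)C(N)=O` is the lower of the two numbers recorded so far: in a physicochemical assay for lipophilicity, read by HPLC, at pH 7.5 (on this read-out lower numbers stand for lower lipophilicity and higher numbers for higher lipophilicity), compound 1 gives 2, while compound 2 `CCOc1ccccc1-c1ccc(-c2nc3cnccc3c(NC(COC)C(N)=O)c2C#N)cc1` gives 2.8 in this assay, a gap beyond the usual scatter. Compound 3 `CC[C@@H](Nc1c(C#N)c(-c2ccc(-c3ccccc3OC)cc2)nc2cnccc12)C(N)=O` differs from compound 1 in one place: 2-methoxyphenyl in place of 3-methylpyridin-2-yl on an aromatic carbon. Within the data shown here, no measured pair with exactly this change exists, so the step from compound 1 to compound 3 in this assay is estimated as an increase, a number 0.70 log units higher from compound 1 to compound 3 (beyond the scatter), since compound 2, which also carries a six-membered aromatic ring of carbon only at that place, gives 2.8. Compound 3 is expected to give 2.7, within 2.3 to 3.1.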

Compound 3, distribution coefficient: 2.7
The estimate for compound 3 equals the measured number at the digits printed, within the range that was stated.
By their numbers in this assay, from the lowest: compound 1; then compounds 3 and 2 (each within the scatter of the next).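

In this assay, 2-methoxyphenyl in place of 3-methylpyridin-2-yl, on an aromatic carbon para to a large group, gives a number 0.70 log units higher from compound 1 to compound 3 (beyond the scatter) with all else held constant. Among these compounds, this is the first one-place pair at this position, so the size of the change can now be read directly rather than through compound 2, which differs in more than one place. Nothing at hand bears on the cause of this step. Going by these compounds, the swap changes the ring and its substituent together, so their separate contributions remain open. A 2-methylphenyl or 3-methoxypyridin-2-yl group at this place would separate them.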